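Replacing the ring-bearing amide group of compound 1

The source may hold more compounds than are shown below. What is called first, only, known or untested is meant among the compounds shown, and "the series" means these compounds.

Measured in a functional assay on HT-29 cells (Homo sapiens) for inhibition, read by CellTiter-Glo, with a stated time of 72 h; on this read-out higher numbers stand for lower toxicity in this test and lower numbers for higher toxicity in this test
- compound 1 `CC1=C(CC(=O)N2CCN(c3ccncc3)CC2)c2cc(F)ccc2/C1=C\c1ccc([S+](C)[O-])cc1` gives 9200 nM
- compound 2 `CC1=C(CC(=O)N2CCN(c3ccncc3)CC2)c2cc(F)ccc2/C1=C\c1nc2ccccc2s1` gives 5250 nM
- compound 3 `CC1=C(CC(=O)NCCN2CCCC2)c2cc(F)ccc2/C1=C\c1ccncc1` gives 2680 nM

Compound 1 sits at the top end of this small set together with compound 2, since their two numbers lie within the usual scatter of each other. Compound 3 shows a clearly lower number, which means higher toxicity in this test.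

Compound 4 `CC1=C(CC(=O)N(C)CCN(C)S(C)(=O)=O)c2cc(F)ccc2/C1=C\c1ccc([S+](C)[O-])cc1` has not yet been measured. It differs from compound 1 in one place methyl(2-(methyl(methylsulfonyl)amino)ethyl)amino in place of 4-(pyridin-4-yl)piperazin-1-yl on a carbonyl carbon and so carries a chain with no ring on its carbonyl carbon. Going by the values given here, the only measured step is a 1.8-fold lower number from compound 1 to compound 2 (0.24 log units; within the scatter) and it changes a different group, so it offers no direct guide to this swap. Compound 3 also carries another group on its carbonyl carbon, but it differs from compound 1 elsewhere as well, so its number cannot be credited to that group alone.

With no direct evidence, the estimate stays close to compound 1 (at 9200 nM) and no step beyond the scatter is expected. The estimate is a 1.2-fold higher number from compound 1 to compound 4 (0.08 log units; within the scatter) in this assay and its uncertainty is wide. For compound 4 the expected value is 11000 nM (estimated range 4000 nM to 30000 nM).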

Compound 4, half-maximal cytotoxic concentration: 12400 nM
Beside the measured number, compound 4's estimate is 1.1-fold (0.05 log units) below it; measured number inside the range.
By their numbers in this assay, from the lowest: compounds 3, 2, 1 and 4 (each within the scatter of the next, the first and the last beyond it).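

In this assay, the group on the carbonyl carbon of compound 1 can be exchanged for a very different one with only a small effect: a 1.3-fold higher number from compound 1 to compound 4 (0.13 log units; within the scatter). The entering methyl(2-(methyl(methylsulfonyl)amino)ethyl)amino has no ring, whereas the leaving 4-(pyridin-4-yl)piperazin-1-yl has two, so at this place in this pair, losing both rings does not move the number beyond the usual scatter. Going by these compounds alone, the earlier step changed a different group, which makes this the first reading of a change at this position with the rest of compound 1 held fixed.

As far as these compounds go, how a plain dimethylamino group, a morpholine ring or a chain ending in a carboxylic acid would behave on this carbonyl carbon remains open. Nothing measured here explains why the number stayed within the scatter.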